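Trimming the ester tail on the piperazine nitrogen

A few compounds are considered here, and "the series" means these few. Any claim that something is new, unique, unknown or untested is made for them only; others in the source may bear on it.

Measured compounds in a functional assay on HeLa cells (Homo sapiens) for cytotoxicity, read by MTT assay, with a stated time of 48 h; on this read-out lower numbers stand for stronger inhibition and higher numbers for weaker inhibition:
- compound 1, `CCN(CC)c1ccc2cc(C(=O)c3ccc(N4CCN(C(=O)CN5CCNCC5)CC4)cc3)oc2c1`: 1350 nM
- compound 2, `CCN(CC)c1ccc2cc(C(=O)c3ccc(N4CCN(C(=O)CN5CCN(S(=O)(=O)c6ccc(F)cc6)CC5)CC4)cc3)oc2c1`: 16700 nM
- compound 3, `CCOC(=O)CN1CCN(CC(=O)N2CCN(c3ccc(C(=O)c4cc5ccc(N(CC)CC)cc5o4)cc3)CC2)CC1`: 22100 nM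

Compound 3 gives the highest number of the three. Its nearest neighbour is compound 2, and the gap a 1.3-fold higher number from compound 2 to compound 3 (0.12 log units; within the scatter) lies within the scatter; the gap to compound 1, a 16-fold higher number from compound 1 to compound 3 (1.21 log units; beyond the scatter), lies beyond it.

Compound 4, `CCN(CC)c1ccc2cc(C(=O)c3ccc(N4CCN(C(=O)CN5CCN(CC(C)=O)CC5)CC4)cc3)oc2c1`, differs from compound 3 in one place: methyl in place of ethoxy on a carbonyl carbon. The change sits on a carbonyl carbon whose other neighbour is a saturated chain carbon, so the substituent on the ring nitrogen stays but loses its ethoxy part.

Going by the values given here, two measured steps bear on this position. Adding a (4-fluorophenyl)sulfonyl to the bare ring nitrogen gave a 12-fold higher number from compound 1 to compound 2 (1.09 log units; beyond the scatter), and adding an (ethoxycarbonyl)methyl gave a 16-fold higher number from compound 1 to compound 3 (1.21 log units; beyond the scatter); swapping one for the other gave a 1.3-fold higher number from compound 2 to compound 3 (0.12 log units; within the scatter). Any substituent on that nitrogen has so far cost activity by about the same amount, while the kind of substituent mattered little. Compound 4 still carries a substituent there, so the number is expected to stay close to compound 3, with at most a small move downwards: a 1.5-fold lower number from compound 3 to compound 4 (0.17 log units; within the scatter). The estimate for compound 4 in this assay is 15000 nM, ranging from 5000 nM to 40000 nM.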

Compound 4, half-maximal inhibitory concentration: 2760 nM
Compound 4: middle estimate off by 5.4-fold (0.74 log units), on the high side, outside the stated range (below it).
By their numbers in this assay, from the lowest: compound 1; then compound 4; then compounds 2 and 3 (each within the scatter of the next).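

Methyl in place of ethoxy on the carbonyl carbon gives an 8.0-fold lower number from compound 3 to compound 4 (0.90 log units; beyond the scatter) in this assay, so the kind of substituent on this ring nitrogen does matter, and a change at its far end can make a large difference. The 2-oxopropyl group also separates from the (4-fluorophenyl)sulfonyl group, with a 6.1-fold lower number from compound 2 to compound 4 (0.78 log units; beyond the scatter) as the step, yet a 2.0-fold higher number from compound 1 to compound 4 (0.31 log units; beyond the scatter) shows that compound 1, with hydrogen on that nitrogen, still has the lowest number of the four. Nothing measured here explains the gain.

From the compounds shown here alone, it remains open whether other ends on this chain, such as a carboxylic acid, an amide or a longer alkyl chain on the carbonyl carbon, would behave like acetyl or like ethoxycarbonyl. Going by these compounds, it is also open whether a plain methyl on the ring nitrogen would come closer to compound 1.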